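Pentyl to 3-methoxyphenyl on an aromatic nitrogen

The compounds below may be only part of what the source reports. "The series", "measured", "known", "first", "only" and "open" are said of these compounds alone.

In a functional assay on HeLa cells (Homo sapiens) for antiproliferative activity, read by MTT assay, with a stated time of 72 h (on this read-out lower numbers stand for stronger inhibition and higher numbers for weaker inhibition), compound 1 `COc1cc(-c2nccn2C)cc(OC)c1OC` gives > 100000 nM, which is a limit and not a number. Compound 2 `CCn1ccnc1-c1cc(OC)c(OC)c(OC)c1` gives > 100000 nM, again a limit. Compound 3 `CCCCCn1ccnc1-c1cc(OC)c(OC)c(OC)c1` gives > 100000 nM, also a limit, so it has no measured position of its own. The whole set stands at one ceiling: the limit of > 100000 nM in this assay, at which 3 of the 3 values shown sit.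

Compound 4 `COc1cccc(-n2ccnc2-c2cc(OC)c(OC)c(OC)c2)c1` carries 3-methoxyphenyl in place of pentyl on an aromatic nitrogen. Among the compounds with values here, the steps that bear on this change are the chain extensions at that nitrogen: a step that the two limits leave unreadable from compound 1 to compound 2, a step that the two limits leave unreadable from compound 1 to compound 3 and a step that the two limits leave unreadable from compound 2 to compound 3. None has a readable size, so they offer no measure for an aromatic ring in that place. With a step that the two limits leave unreadable from compound 2 to compound 3 as the nearest guide, any shift is expected to be toward stronger inhibition, and it may not be a large one: an at least 2.5-fold lower number from compound 3 to compound 4 (0.39 log units; beyond the scatter). Another limit is expected about as often as a number. For compound 4 the estimate is 40000 nM, with an expected range from 5000 nM to 100000 nM.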

Compound 4, half-maximal inhibitory concentration: 11000 nM
Beside the measured number, compound 4's estimate is 3.6-fold (0.56 log units) above it, and the stated range covers the measured number.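

In this assay compound 4 is the only compound shown that comes off the ceiling and gives a number: the limit of > 100000 nM in this assay, at which 3 of the 4 values shown sit. Within the data shown here, putting 3-methoxyphenyl on the aromatic nitrogen yields the first readable steps at this position: an at least 9.0-fold lower number from compound 3 to compound 4 (0.95 log units; beyond the scatter), an at least 9.0-fold lower number from compound 2 to compound 4 (0.95 log units; beyond the scatter) and an at least 9.0-fold lower number from compound 1 to compound 4 (0.95 log units; beyond the scatter). The steps among compound 1, compound 2 and compound 3 cannot be read, so the change from a saturated chain to an aromatic ring is the only one here with a measurable size.

The compounds shown leave open whether the ring alone accounts for these steps or the methoxy on it takes part, which a plain phenyl would help to separate. From the compounds shown here alone, how a benzyl group or a ring bearing an amine would compare on this nitrogen also remains open.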